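Removing a methyl from the side chain of a curcumin-like series

The compounds below may be only part of what the source reports. "The series", "measured", "known", "first", "only" and "open" are said of these compounds alone.

Of the compounds shown here, three of one family have been measured in a functional assay on Caco-2 cells (Homo sapiens) for activation, read by fluorescence, tested at 10 uM; a lower number here means a stronger effect, a higher number a weaker effect of the compound at the concentration tested. Compound 1, with the structure `COc1cc(/C=C/C(=O)/C=C(/C=C/c2ccc(O)c(OC)c2)NCCO)ccc1O`, gives 96.6%. Compound 2, with the structure `COCCNC(=C\C(=O)/C=C/c1ccc(O)cc1)/C=C/c1ccc(O)cc1`, gives 89.7%. Compound 3, with the structure `COCCNC(=C\C(=O)/C=C/c1ccc(O)c(OC)c1)/C=C/c1ccc(O)c(OC)c1`, gives 75.6%. The two values of compound 1 and compound 2 lie within the usual scatter of each other, so no order is claimed between them, whereas compound 3 stands apart from both beyond the scatter.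

One change is seen directly: hydrogen in place of methyl on an oxygen on a saturated carbon. That change made a number 21 percentage points higher from compound 3 to compound 1 (beyond the scatter), that is, the effect at the tested concentration became weaker.

The unmeasured compound 4, with the structure `O=C(/C=C(/C=C/c1ccc(O)cc1)NCCO)/C=C/c1ccc(O)cc1`, arises from compound 2 by the same change, (hydrogen in place of methyl on an oxygen on a saturated carbon). The surroundings of the place are the same word for word in both cases, so this is the same change. The two cores, those of compound 2 and compound 3, differ in more than one place, and the difference between them is not broken down here.

Because a number 21 percentage points higher from compound 3 to compound 1 (beyond the scatter) weakened the effect, compound 4 is expected to show a weaker effect than compound 2, with an estimated a number 10.3 percentage points higher from compound 2 to compound 4 (beyond the scatter), though the read-out cannot rise much further than where compound 2 and compound 1 already stand. Compound 4 is therefore estimated at 100%, expected between 90% and 112%.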

Compound 4, a percentage reported as activity, at one concentration (the size of the read-out at that concentration, not a potency): 87.1%
Compound 4: middle estimate off by 12.9 percentage points, on the high side, outside the stated range (below it).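

On the core of compound 2, exchanging 2-methoxyethyl for 2-hydroxyethyl in this assay gives a number 2.6 percentage points lower from compound 2 to compound 4 (within the scatter), so on this core the exchange has no effect that can be told apart from the ordinary spread of repeated measurements. Going by these compounds alone, the earlier pair on the other core behaved differently, which shows that the size of the step does not carry over from one core to the other, even though the surroundings of the exchanged group are the same in both cases: the same change on two cores in this assay, a number 21 percentage points higher (beyond the scatter) from compound 3 to compound 1 and a number 2.6 percentage points lower (within the scatter) from compound 2 to compound 4, 23.6 percentage points apart, beyond the scatter of two such steps This does not show which feature of the cores accounts for the gap, since they differ in more than one place, and with only one pair on each core it gives no rule for what the exchange would do on a third core.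

The compounds shown leave open how the two cores would respond to side chains other than these two, such as a longer chain ending in hydroxy, or a chain ending in an amine or a carboxylic acid. They also leave open which single difference between the cores decides whether removing the methyl matters in this assay.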